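The compounds below may be only part of what the source reports. "The series", "measured", "known", "first", "only" and "open" are said of these compounds alone.

Compound 1 `O=C(/C=C/C(=O)N1C/C(=C\c2ccccc2)C(=O)/C(=C/c2ccccc2)C1)Nc1ccccc1`: in a functional assay on CCRF-CEM cells (Homo sapiens) for cytotoxicity (on this read-out higher numbers stand for weaker inhibition and lower numbers for stronger inhibition), compound 1 gives 1100 nM.
Compound 2 `Cc1ccc(NC(=O)/C=C/C(=O)N2C/C(=C\c3ccc([N+](=O)[O-])cc3)C(=O)/C(=C/c3ccc([N+](=O)[O-])cc3)C2)cc1`: in this assay compound 2 gives 890 nM.

Of these two numbers, compound 2 has the lower one, yet its gap to compound 1 lies within the scatter, so the two cannot be told apart. Compound 3 `O=C(/C=C/C(=O)N1C/C(=C\c2ccc([N+](=O)[O-])cc2)C(=O)/C(=C/c2ccc([N+](=O)[O-])cc2)C1)Nc1ccc(Cl)cc1` has not yet been measured. It differs from compound 2 in one place: chloro in place of methyl on an aromatic carbon. Among the measured compounds shown here, no measured pair shows a change of this kind here, so nothing beyond a small shift is expected; the step of a 1.1-fold lower number from compound 2 to compound 3 (0.05 log units; within the scatter) is an estimate only. Compound 3 is expected to give 800 nM, between 300 nM and 2500 nM.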

Compound 3, half-maximal inhibitory concentration: 810 nM
Compound 3: middle estimate off by 1.0-fold (0.01 log units), on the low side; measured number inside the range.
By their numbers in this assay, from the lowest: compounds 3, 2 and 1 (each within the scatter of the next).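

Putting chloro in place of methyl on this aromatic carbon, para to a large group, gives a 1.1-fold lower number from compound 2 to compound 3 (0.04 log units; within the scatter) in this assay. Among the compounds shown here, at this position, then, the two groups cannot be told apart in this one pair, a result the earlier compounds could not show. No independent data on the compounds bear on this result.

From the compounds shown here alone, whether an amine or a carboxylic acid here would move the number beyond the scatter remains open. Compound 1 differs from compound 2 and compound 3 in more than one place, so the contribution of the nitro groups also remains unresolved.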